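Chloro in place of fluoro on compound 2

The source may report more compounds than this note shows. Statements on the series, on what has been measured and on what is new or still open speak of the compounds shown alone.

Of the compounds shown here, three sharing one core have been measured in a functional assay on HeLa S3 cells (Homo sapiens) for cytotoxicity, read by XTT assay, with a stated time of 3 days; a lower number here means a stronger inhibitor, a higher number a weaker inhibitor. Compound 1 `OC[C@H]1O[C@@H](n2cc(F)c3c(-c4cccs4)ncnc32)[C@H](O)[C@@H]1O` gives 4300 nM, compound 2 `OC[C@H]1O[C@@H](n2cc(F)c3c(-c4ccoc4)ncnc32)[C@H](O)[C@@H]1O` gives 170 nM, and compound 3 `OC[C@H]1O[C@@H](n2cc(F)c3c(-c4cc[nH]c4)ncnc32)[C@H](O)[C@@H]1O` gives 8900 nM. Compound 2 thus holds the lowest number of the three. The measured steps are a 25-fold lower number from compound 1 to compound 2 (1.40 log units; beyond the scatter), a 2.1-fold higher number from compound 1 to compound 3 (0.32 log units; beyond the scatter) and a 52-fold higher number from compound 2 to compound 3 (1.72 log units; beyond the scatter).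

Compound 4 `OC[C@H]1O[C@@H](n2cc(Cl)c3c(-c4ccoc4)ncnc32)[C@H](O)[C@@H]1O` keeps the furan-3-yl group of compound 2 but carries chloro in place of fluoro on an aromatic carbon. For the measured compounds named here, none of the measured steps touches this place, since fluoro stays fixed in all three compounds. They therefore give no direction for the exchange, and no step beyond the scatter is expected. The estimated change is a 1.1-fold lower number from compound 2 to compound 4 (0.05 log units; within the scatter). The range is kept wide, as a 52-fold higher number from compound 2 to compound 3 (1.72 log units; beyond the scatter) shows how far a single exchange can move this series. In this assay, compound 4 is estimated at 150 nM, with an expected range from 40 nM to 700 nM.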

Compound 4, half-maximal inhibitory concentration: 2700 nM
Compound 4: the middle estimate sits 18-fold (1.26 log units) below what was measured, and the stated range ends below it.
By their numbers in this assay, from the lowest: compound 2; then compounds 4 and 1 (each within the scatter of the next); then compound 3.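

In this assay, the place held by fluoro proves sensitive: with the furan-3-yl group kept, chloro in place of fluoro gives a 16-fold higher number from compound 2 to compound 4 (1.20 log units; beyond the scatter) and so removes much of the advantage that compound 2 has. For the compounds shown here, the earlier steps exchanged only the aromatic ring group, so this is the first sign that this halogen alone can move the number by a large step, with fluoro giving the lower number of the pair. Nothing measured here explains the size of this step.

Going by these compounds, whether chloro would have a similar effect alongside the thiophen-2-yl or 1H-pyrrol-3-yl group stays open, as chloro appears here only with furan-3-yl. Also open, on these data alone, is how hydrogen, bromo or methyl at this place would compare with fluoro and chloro.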